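A few compounds are considered here, and "the series" means these few. Any claim that something is new, unique, unknown or untested is made for them only; others in the source may bear on it.

Among the compounds with values here, in an ADME assay on HEK293 cells (Homo sapiens) for cytotoxicity, read by MTT assay, with a stated time of 48 h (on this read-out higher numbers stand for weaker inhibition and lower numbers for stronger inhibition), compound 1 `CN(C)c1ccc(/C=C2/S/C(=N/c3ccccc3)N(Cc3ccncc3)C2=O)cc1` gives 122000 nM and compound 2 `COc1ccc(/C=C2/S/C(=N/c3ccccc3)N(Cc3ccncc3)C2=O)cc1OC` gives 171000 nM so compound 2 stands within the scatter of the only other measured compound. Compound 3 `O=C1/C(=C\c2cccc(Cl)c2)S/C(=N/c2ccccc2)N1Cc1ccncc1` has not yet been measured. It carries 3-chlorophenyl in place of 3,4-dimethoxyphenyl on a double-bonded chain carbon bound to a double-bonded ring carbon, a change counted as 3-chlorophenyl in place of 3,4-dimethoxyphenyl on a double-bonded chain carbon bound to a double-bonded ring carbon on the shared core. Within the data shown here, one measured step bears on this place: a 1.4-fold higher number from compound 1 to compound 2 (0.15 log units; within the scatter) is the result of the exchange of 4-(dimethylamino)phenyl for 3,4-dimethoxyphenyl there. That single step is thin evidence, and neither measured compound carries chlorine. Even so, no step beyond the scatter is expected. The expected change is a 1.2-fold lower number from compound 2 to compound 3 (0.09 log units; within the scatter) in this assay as estimated from that one step. For compound 3 the estimated value is 140000 nM with an expected range from 65000 nM to 300000 nM once it is measured.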

Compound 3, half-maximal inhibitory concentration: 71800 nM
The estimate for compound 3 lay 1.9-fold (0.29 log units) above the measured number; measured number inside the range.
By their numbers in this assay, from the lowest: compounds 3, 1 and 2 (each within the scatter of the next, the first and the last beyond it).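

In this assay this position now gives a step beyond the scatter: 3-chlorophenyl in place of 3,4-dimethoxyphenyl brings a 2.4-fold lower number from compound 2 to compound 3 (0.38 log units; beyond the scatter) and so shows that the place can respond to the group it carries, which the earlier pair did not show. Against 4-(dimethylamino)phenyl the same entering group gives only a 1.7-fold lower number from compound 1 to compound 3 (0.23 log units; within the scatter) and therefore stays within the scatter, so the effect of 3-chlorophenyl depends on which of the two groups it is compared with. Nothing measured here explains this difference.

The compounds shown leave open whether the chlorine or the removal of the two methoxy groups accounts for the step. They also leave open how a phenyl ring carrying fluorine, bromine, a carboxylic acid or a primary amine would read at this place.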